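This account rests on a few compounds, and the source may have more. Where it says the series, first, only, none or still open, it means among the compounds named here.

Measured compounds:
compound 1, `Cc1c(C(=O)Nc2ccccc2)sc(NC(=O)N2CCOCC2)c1C(N)=O`: "not determined" (no result reported) in an ADME assay on HepG2 cells (Homo sapiens) for cytotoxicity, read by XTT assay, with a stated time of 2 days; on this read-out lower numbers stand for higher toxicity in this test and higher numbers for lower toxicity in this test
compound 2, `Cc1c(C(=O)Nc2ccccc2)sc(NC(=O)c2cc(Cl)cc(Cl)c2)c1C(N)=O`: 49500 nM

Compound 2 is the only one of the two with a number in this assay, so it stands alone; compound 1 gave no result, and nothing can be said about the step between them. Compound 2 shows a modest level of toxicity toward the cells, with its value sitting in the range where many compounds are regarded as only weakly harmful.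

Compound 3, `Cc1c(C(=O)Nc2ccccc2)sc(NC(=O)c2ccc(S(C)(=O)=O)cc2)c1C(N)=O`, has not yet been measured. It differs from compound 2 in one place: 4-(methylsulfonyl)phenyl in place of 3,5-dichlorophenyl on a carbonyl carbon. For the measured compounds named here, no pair of measured compounds shows what such a change does in this assay, so there is no measured step to lean on. With only the value of compound 2 as anchor, the expectation is for a change of about a 1.2-fold higher number from compound 2 to compound 3 (0.08 log units; within the scatter), which lies within the usual scatter rather than clearly in either direction. Compound 3 is therefore expected to give about 60000 nM, most likely between 25000 nM and 140000 nM.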

Compound 3, half-maximal cytotoxic concentration: > 100000 nM
Compound 3 was reported as a limit (the forecaster's own chance of this, stated with the estimate: 30%); middle value at least 1.6-fold (0.22 log units) away from the limit.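

In this assay, for the compounds shown here, the change to 4-(methylsulfonyl)phenyl in place of 3,5-dichlorophenyl on a carbonyl carbon gives the first readable step at this position, an at least 2.0-fold higher number from compound 2 to compound 3 (0.30 log units; that floor lies within the scatter), and this step offers no sign of higher toxicity in this test. Compound 3 gives > 100000 nM, which is a limit of the assay and not a number. Only a floor for the step can therefore be read, and its true size remains unknown: the limit of > 100000 nM in this assay, at which 1 of the 3 values shown sits.

The compounds shown do not separate the loss of the two chlorine atoms from the gain of the methylsulfonyl group, so a plain phenyl ring, or one carrying a single chlorine atom, would be needed to tell these two parts of the change apart. As far as these compounds go, it also remains open how a phenyl ring bearing an amine or a carboxylic acid would behave at this position, and the step to compound 1 cannot be read, as it has no reported result.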